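This account rests on a few compounds, and the source may have more. Where it says the series, first, only, none or still open, it means among the compounds named here.

Three compounds share one core and were measured in a functional assay on HeLa cells (Homo sapiens) for antiproliferative activity, read by WST assay, with a stated time of 72 h; a higher number here means a weaker inhibitor, a lower number a stronger inhibitor. Compound 1 `COC(=O)/C=C/c1ccc(NCc2cc(Br)ccc2O)cc1` gives 7820 nM, the lowest of the three numbers. Compound 2 `COC(=O)/C=C/c1ccc(NCc2cc(Br)cc(Br)c2O)cc1` gives 35400 nM, and the step of a 4.5-fold higher number from compound 1 to compound 2 (0.66 log units; beyond the scatter) shows that adding a second bromo weakened inhibition. Compound 3 `COC(=O)/C=C/c1ccc(NCc2cc(Cl)cc(Cl)c2O)cc1` gives 25900 nM, also above compound 1.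

Compound 4 `COC(=O)/C=C/c1ccc(NCc2cc([N+](=O)[O-])ccc2O)cc1` differs from compound 1 by one change: nitro in place of bromo on an aromatic carbon. Among the measured compounds shown here, no measured step swaps a bromo for a nitro, so the only guidance is that enlarging this ring raised the number from compound 1 to compound 2. The expected step in this assay is therefore small and uncertain, a 1.3-fold higher number from compound 1 to compound 4 (0.11 log units; within the scatter). Compound 4 is estimated at 10000 nM, within a range from 3000 nM to 33000 nM.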

Compound 4, half-maximal inhibitory concentration: 16000 nM
Compound 4: the middle estimate sits 1.6-fold (0.20 log units) below what was measured; the measured number falls inside the stated range.
By their numbers in this assay, from the lowest: compound 1; then compounds 4, 3 and 2 (each within the scatter of the next, the first and the last beyond it).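

At this position, para to a hydroxy group, nitro in place of bromo gives a 2.0-fold higher number from compound 1 to compound 4 (0.31 log units; beyond the scatter) in this assay, so the group held here affects the number. The earlier step added a second bromo and left this bromo in place, so it could not show this. No measurement at hand gives a reason for this step.

From the compounds shown here alone, whether an amine, a methoxy group or a carboxylic acid at this position would give a lower or a higher number remains open. So does whether any group here can bring the number below that of the bromo in compound 1.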